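Adding methoxy to compound 2: what size of step?

The source may hold more compounds than are shown below. What is called first, only, known or untested is meant among the compounds shown, and "the series" means these compounds.

Measured so far:
Compound 1 `O=C(Nc1ccccc1)Nc1cccc(Nc2nccc(Nc3ccc4nc[nH]c4c3)n2)c1` gives 11000 nM
Compound 2 `O=C(Nc1ccccc1)Nc1cccc(Nc2nccc(Nc3ccc4cn[nH]c4c3)n2)c1` gives 8200 nM
Compound 3 `O=C(Nc1ccccc1)Nc1cc(Nc2nccc(Nc3ccc4cn[nH]c4c3)n2)ccc1O` gives 25000 nM

These values all come from a functional assay on HepG2 cells (Homo sapiens) for inhibition, read by fluorescence and resazurin assay, with a stated time of 72 h (on this read-out lower numbers stand for stronger inhibition and higher numbers for weaker inhibition), and are the whole record so far. Compound 2 sits at the low end of this small set, but that place is shared: its nearest neighbour is reached by a 1.3-fold lower number from compound 1 to compound 2 (0.13 log units; within the scatter) and no order can be drawn from that.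

The compound awaiting measurement is compound 4 `COc1ccc(NC(=O)Nc2ccccc2)cc1Nc1nccc(Nc2ccc3cn[nH]c3c2)n1`, which is compound 2 with methoxy in place of hydrogen on an aromatic carbon, ortho to a large group and para to a (phenylcarbamoyl)amino group. The counted change is methoxy in place of hydrogen on an aromatic carbon in full.

Among the compounds with values here, only one measured step bears on this. It puts hydroxy on the same ring, at another carbon, and shows a 3.0-fold higher number from compound 2 to compound 3 (0.48 log units; beyond the scatter) as its result. The step between the two fused ring groups concerns a different part of the molecule and offers no guide. With a single precedent, a small upward move is expected rather than a large one, and it may not leave the scatter. The expected change is a 1.8-fold higher number from compound 2 to compound 4 (0.26 log units; within the scatter) in this assay on this evidence. Compound 4 is estimated at 15000 nM with an expected range from 6000 nM to 38000 nM in this assay.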

Compound 4, half-maximal inhibitory concentration: 6500 nM
Estimate against measurement, compound 4: 2.3-fold (0.36 log units) above; measured number inside the range.
By their numbers in this assay, from the lowest: compounds 4, 2 and 1 (each within the scatter of the next); then compound 3.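

In this assay, methoxy in place of hydrogen on this aromatic carbon, ortho to a large group and para to a (phenylcarbamoyl)amino group, produces a 1.3-fold lower number from compound 2 to compound 4 (0.10 log units; within the scatter), so the change leaves no readable effect at this position. Within the data shown here, the only earlier step on this ring, with hydroxy on another carbon, was a 3.0-fold higher number from compound 2 to compound 3 (0.48 log units; beyond the scatter) and lay beyond the scatter, so the new step shows that adding a group to this ring does not always move the number beyond the scatter, with compound 3 remaining the one case that does. No measurement among these data accounts for the difference between the two steps.

The two steps differ in both the group and the carbon that carries it, so the compounds shown cannot tell whether the group or its place separates them, and hydroxy on the methoxy-bearing carbon or methoxy on the hydroxy-bearing carbon would be needed to settle that. As far as these compounds go, it also remains open whether a larger ethoxy group, an amine or a carboxylic acid on this same carbon would stay as close to compound 2 as methoxy does.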